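Compound 3 in the PC-3 cytotoxicity test

The source may report more compounds than this note shows. Statements on the series, on what has been measured and on what is new or still open speak of the compounds shown alone.

Compound 1 `COc1cc(-n2c(-c3ccccc3)cn(C(C)=O)c2=O)cc(OC)c1OC`: > 50000 nM
Compound 2 `COc1cc(-n2c(-c3ccc(F)cc3F)cn(C(C)=O)c2=O)cc(OC)c1OC`: 34300 nM

These two compounds share one core and differ only in the aryl group on an aromatic carbon. Within the data shown here, in a functional assay on PC-3 cells (Homo sapiens) for cytotoxicity, read by MTT assay, with a stated time of 48 h (a lower number here means a stronger inhibitor, a higher number a weaker inhibitor), compound 2 gives 34300 nM, the only true number so far. Compound 1 gives > 50000 nM, which is a limit and not a number.

Compound 3 `COc1ccc(-c2cn(C(C)=O)c(=O)n2-c2cc(OC)c(OC)c(OC)c2)cc1N` carries 3-amino-4-methoxyphenyl in place of the 2,4-difluorophenyl of compound 2, on the same aromatic carbon of the five-membered aromatic ring: 3-amino-4-methoxyphenyl in place of 2,4-difluorophenyl on an aromatic carbon.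

Among the measured compounds shown here, only one measured step bears on this change: an at least 1.4-fold lower number from compound 1 to compound 2 (0.16 log units; that floor lies within the scatter). Its floor lies within the scatter, so it gives a weak guide, and it involved a different group from the one entering here. A clear move toward a lower number in this assay is still expected, though this is an uncertain judgement and the range must stay wide. The estimate for compound 3 is 500 nM, with an expected range of 15 nM to 25000 nM. This estimate means an expected 69-fold lower number from compound 2 to compound 3 (1.84 log units; beyond the scatter).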

Compound 3, half-maximal inhibitory concentration: 21400 nM
Compound 3: the middle estimate sits 43-fold (1.63 log units) below what was measured, within the range that was stated.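

In this assay, 3-amino-4-methoxyphenyl in place of 2,4-difluorophenyl gives a 1.6-fold lower number from compound 2 to compound 3 (0.20 log units; within the scatter), so the two groups cannot be told apart at this position, even though the entering group brings a hydrogen-bond donor and acceptors that the leaving group lacks. Among these compounds, measured against plain phenyl, the change gives an at least 2.3-fold lower number from compound 1 to compound 3 (0.36 log units; beyond the scatter), the first step in this short series that clears the scatter. Compound 1 has only a limit and not a true number, so this step is a floor and its full size stays unknown: the limit of > 50000 nM in this assay, at which 1 of the 3 values shown sits.

On these data alone, compound 3 carries an amine and a methoxy group together, so the share of each stays open, as does how a phenyl ring bearing a carboxylic acid or a nitrile would read on this carbon. Also open, as far as these compounds go, is whether any group here can bring a much lower number, and what the acetyl group of the shared core contributes, as it stays the same in all three compounds.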